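Swapping Nitro for Methoxy at the Assay Limit

The source may report more compounds than this note shows. Statements on the series, on what has been measured and on what is new or still open speak of the compounds shown alone.

Compound 1 `Nc1ccccc1NC(=O)c1ccc(NCC(=O)Nc2ccc([N+](=O)[O-])cc2)cc1` gives > 100000 nM in a functional assay on HCT-116 cells (Homo sapiens) for inhibition, read by MTT assay, with a stated time of 2 days (a lower number here means that less compound is tolerated, a higher number that more compound is tolerated), and this reading is a limit of the assay, not a number. Compound 2 `Nc1ccccc1NC(=O)CCCNCC(=O)Nc1ccccc1Cl` gives > 100000 nM in this assay too, again a limit. That makes the limit of > 100000 nM in this assay, at which 2 of the 2 values shown sit, the whole of the measured picture so far.

Compound 3 `COc1ccc(NC(=O)CNc2ccc(C(=O)Nc3ccccc3N)cc2)cc1` keeps the core of compound 1 and alters one group. The change methoxy in place of nitro on an aromatic carbon is methoxy in place of nitro on an aromatic carbon, para to a large group. Among the measured compounds shown here, no measured pair shows what this swap does. Compound 1 gives > 100000 nM as a limit, and that limit is the only anchor for an expectation. The expected move, a number no higher from compound 1 to compound 3 (the limit leaves the size open) in this assay, is none beyond the scatter. The estimated value for compound 3 is 100000 nM in this assay, with an expected range from 40000 nM to 250000 nM and a good chance that only a limit is reported.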

Compound 3, concentration lethal to 50% of the cells: > 100000 nM
Compound 3 ended at the assay's limit (the forecaster's own chance of this, stated with the estimate: 70%); the middle value sits exactly at the limit.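

Among the compounds shown here, compound 1 and compound 3 each give only a limit in this assay, and no step between them can be read. The compounds shown leave open whether methoxy in place of nitro changes the lethal concentration at all, and what a measured number would look like.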